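Hydrogen for methyl on the ring amine nitrogen

The source may hold more compounds than are shown below. What is called first, only, known or untested is meant among the compounds shown, and "the series" means these compounds.

compound 1 `CN1CCN(c2ccc(Nc3ncc4c(n3)N(C3CCCC3)CC(=O)N4)cc2)CC1`: 26100 nM
compound 2 `CN1CCN(c2ccc(Nc3ncc4c(n3)N(C3CCCC3)CC(=O)N4)nc2)CC1`: > 30000 nM

In a functional assay on MDA-MB-231 cells (Homo sapiens) for inhibition, read by MTT assay, with a stated time of 48 h (a lower number here means a stronger inhibitor, a higher number a weaker inhibitor), compound 1 gives 26100 nM. Compound 2 shows no number here, only a limit of the assay, > 30000 nM. This is the limit of > 30000 nM in this assay, at which 1 of the 2 values shown sits. Compound 3 `O=C1CN(C2CCCC2)c2nc(Nc3ccc(N4CCNCC4)cn3)ncc2N1` differs from compound 2 by hydrogen in place of methyl on an amine nitrogen in a ring. Within the data shown here, no measured pair shows this change, so the expected step from compound 2 to compound 3 is none beyond the scatter, a step that the limit leaves unreadable from compound 2 to compound 3. Compound 3 is therefore estimated at 40000 nM, in a range from 12000 nM to 120000 nM, most likely reported again as a limit.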

Compound 3, half-maximal inhibitory concentration: > 30000 nM
Compound 3: a limit, no number; the forecaster's own chance of this, stated with the estimate: 70%; the middle value is on the limit's open side.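

Compound 2 and compound 3 both stand at a limit, and no step can be read between them: the limit of > 30000 nM in this assay, at which 2 of the 3 values shown sit.

The compounds shown leave open how far either lies past that limit, and so what the change from 4-methylpiperazin-1-yl to piperazin-1-yl does in this assay.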